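Replacing the oxidised sulfur link with a benzyl sulfanyl group

The source may hold more compounds than are shown below. What is called first, only, known or untested is meant among the compounds shown, and "the series" means these compounds.

Compound 1, `COc1ccc(CCCCCCCCOc2ccc(CSc3cccc(C(=O)O)c3)nc2/C=C/C(=O)O)cc1`: 1000 nM
Compound 2, `COc1ccc(CCCCCCCCOc2ccc(C[S+]([O-])c3cccc(C(=O)O)c3)nc2/C=C/C(=O)O)cc1`: 3200 nM

In a functional assay on the whole organism with Homo sapiens as the target (a lower number here means a stronger inhibitor, a higher number a weaker inhibitor), compound 2 gives the highest of these two numbers; the nearest is compound 1, separated by the step of a 3.2-fold higher number from compound 1 to compound 2 (0.51 log units; beyond the scatter). Compound 3, `COc1ccc(CCCCCCCCOc2ccc(CSCc3cccc(C(=O)O)c3)nc2/C=C/C(=O)O)cc1`, differs from compound 2 by a group of 11 heavy atoms (8 carbon, 2 oxygen, 1 sulfur; one six-membered aromatic ring of carbon only) in place of a group of 11 heavy atoms (7 carbon, 3 oxygen, 1 sulfur; one six-membered aromatic ring of carbon only), on a saturated chain carbon bound to an aromatic carbon. Within the data shown here, the only measured step that bears on this change is a 3.2-fold higher number from compound 1 to compound 2 (0.51 log units; beyond the scatter), which went in the opposite direction when the sulfur link was oxidised; reversing that oxidation while adding one chain carbon is expected to lower the number by about a 3.2-fold lower number from compound 2 to compound 3 (0.51 log units; beyond the scatter). Compound 3 is therefore estimated at 1000 nM, with a range from 400 nM to 2500 nM.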

Compound 3, half-maximal inhibitory concentration: 271 nM
Compound 3: middle estimate off by 3.7-fold (0.57 log units), on the high side; measured number below the stated range.
By their numbers in this assay, from the lowest: compound 3; then compound 1; then compound 2.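

In this assay, 3-carboxybenzyl in place of 3-carboxyphenyl on the sulfur gives a 3.7-fold lower number from compound 1 to compound 3 (0.57 log units; beyond the scatter), so a lower number can be reached at this position without oxidising the sulfur. The larger step, a 12-fold lower number from compound 2 to compound 3 (1.07 log units; beyond the scatter), combines that change with removal of the sulfur oxidation, so it does not show how much each change contributes. No evidence here explains either step. Still open, going by these compounds, is whether a longer chain between the sulfur and the carboxylic acid-bearing ring would lower the number further. A sulfone or an ether oxygen in place of the sulfur also remains untested among these compounds.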